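Removing the azetidine ring from the pyridine of compound 2

The compounds below may be only part of what the source reports. "The series", "measured", "known", "first", "only" and "open" are said of these compounds alone.

Of the compounds shown here, two have so far been measured in an in vitro functional assay on HEK285-7 cells for antagonist activity at prostaglandin D2 receptor 2 (Homo sapiens), read by BRET and beta-arrestin recruitment; a lower number here means a smaller maximal response, a higher number a larger maximal response. Compound 1 `N#Cc1ccc(-c2nc(C(c3ccc(F)cc3)c3ccc(F)cc3)sc2CC(=O)O)cc1` gives 30% in this assay. Compound 2 `O=C(O)Cc1sc(C(c2ccc(F)cc2)c2ccc(F)cc2)nc1-c1ccnc(N2CCC2)c1` gives 80% in this assay and stands highest of the two numbers, with compound 1 as the nearest point well below it. For the measured compounds named here, the only measured step, a number 50 percentage points higher from compound 1 to compound 2 (beyond the scatter), came with 2-(azetidin-1-yl)pyridin-4-yl in place of 4-cyanophenyl on an aromatic carbon.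

Compound 3 `O=C(O)Cc1sc(C(c2ccc(F)cc2)c2ccc(F)cc2)nc1-c1ccncc1` has not yet been measured. It differs from compound 2 by hydrogen in place of azetidin-1-yl on an aromatic carbon. Going by the values given here, the single measured step exchanged the whole ring and brought in the azetidin-1-yl at the same time, so it bears on this smaller change only in part: compound 3 keeps the pyridin-4-yl of compound 2 but loses the azetidin-1-yl, placing it between compounds 1 and 2 in structure. A drop in this assay is therefore expected, smaller than the large measured step. Compound 3 is expected to reach about 55%, within a range from 30% to 80%. The expected change is a number 25 percentage points lower from compound 2 to compound 3 (beyond the scatter).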

Compound 3, largest response reached (reported as efficacy), in percent of the reference or control that the assay uses: 80%
Compound 3: middle estimate off by 25 percentage points, on the low side; measured number inside the range.
By their numbers in this assay, from the lowest: compound 1; then compounds 2 and 3 (each within the scatter of the next).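

In this assay there is no change at the digits printed from compound 2 to compound 3 (within the scatter) when hydrogen replaces azetidin-1-yl, so at this place, next to the ring nitrogen, the whole four-membered ring can go without a change that rises above the scatter. The other new step, a number 50 percentage points higher from compound 1 to compound 3 (beyond the scatter), comes with pyridin-4-yl in place of 4-cyanophenyl and no azetidin-1-yl at all, and it matches the size of the earlier step from compound 1 to compound 2, so among these three compounds the large rise goes with the exchange of the aromatic ring and needs no azetidin-1-yl. No measurement at hand offers an explanation for either result.

As far as these compounds go, only hydrogen and azetidin-1-yl have been seen at this place, so it remains open whether a different group there, such as a methoxy group or a morpholine ring, would also leave the number unchanged. The rise from compound 1 also mixes two differences, the loss of the nitrile and the arrival of the ring nitrogen, and a plain phenyl group in the same place would be needed to tell them apart.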